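A few compounds are considered here, and "the series" means these few. Any claim that something is new, unique, unknown or untested is made for them only; others in the source may bear on it.

Among the compounds with values here, in a functional assay on HEL cells (Homo sapiens) (on this read-out lower numbers stand for higher toxicity in this test and higher numbers for lower toxicity in this test), compound 1 `CCCCCCCCCCc1cc2cn(COCCO)c(O)nc-2n1` gives 32000 nM, the only actual number among the measured compounds. Compound 2 `CCCCc1cc2cn(COCCO)c(=O)nc2o1` is reported at > 200000 nM, which is a limit of the assay. Compound 3 `CCCCCCC#Cc1cc2cn(COCCO)c(=O)nc2o1` is also reported only as a limit, at > 50000 nM. Compound 4 `CCCCCCc1cc2cn(COCCO)c(O)nc-2n1` differs from compound 1 in its chain alone: hydrogen in place of butyl on a saturated chain carbon, six bonds along the chain from an aromatic carbon, with hydrogen in place of butyl on a saturated chain carbon, six bonds along the chain from an aromatic carbon. Within the data shown here, no measured pair shows this change, so its size is uncertain, but a moderate move toward lower toxicity in this assay is expected. The expected change is a 2.8-fold higher number from compound 1 to compound 4 (0.45 log units; beyond the scatter). For compound 4 the estimated value is 90000 nM, with an expected range of 30000 nM to 200000 nM.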

Compound 4, half-maximal cytotoxic concentration: > 200000 nM
Compound 4: a limit, no number; the forecaster's own chance of this, stated with the estimate: 45%; at least 2.2-fold (0.34 log units) between middle value and limit.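

In this assay, hydrogen in place of butyl on a saturated chain carbon, six bonds along the chain from an aromatic carbon, gives an at least 6.2-fold higher number from compound 1 to compound 4 (0.79 log units; beyond the scatter). Within the data shown here, the earlier compounds offered no pair differing in one place, so this is the first sign that this outer part of the chain matters for toxicity in this test. Compound 4 is reported only as a limit, so the step has a floor but no known full size: the limit of > 200000 nM in this assay, at which 2 of the 4 values shown sit.

As far as these compounds go, whether toxicity changes gradually with chain length between these two chains stays open. So does the effect of a longer chain, or of an amine at the chain's end.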